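The compounds below may be only part of what the source reports. "The series", "measured", "known", "first", "only" and "open" are said of these compounds alone.

Compound 1 `CC(C)(C)c1ccc(CNC(=S)NC(c2ccccc2)c2ccc(NS(C)(=O)=O)c(F)c2)cc1`: 100 nM in an assay on CHO cells for displacement of a labelled ligand from transient receptor potential cation channel subfamily V member 1 (Rattus norvegicus); a lower number here means a stronger inhibitor, a higher number a weaker inhibitor. Compound 2 `CC(C)(C)c1ccc(CNC(=S)NC(C)(C)c2ccc(NS(C)(=O)=O)c(F)c2)cc1`: 7700 nM in this assay.

Of these two numbers compound 2 has the higher one, and its gap to compound 1 lies well beyond the usual scatter, so compound 2 is the weaker inhibitor of the pair. Compound 3 `COc1cc(C(C)(C)NC(=S)NCc2ccc(C(C)(C)C)cc2)ccc1NS(C)(=O)=O` differs from compound 2 in one place: methoxy in place of fluoro on an aromatic carbon. Going by the values given here, no measured pair shows this exchange, so the size of its step is uncertain. The expectation is a step from compound 2 to compound 3 of a 1.6-fold higher number from compound 2 to compound 3 (0.19 log units; within the scatter), toward a weaker inhibitor, though one that may not exceed the scatter. Compound 3 is estimated at 12000 nM in this assay, within 4000 nM to 40000 nM.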

Compound 3, inhibition constant: 2890 nM
For compound 3 the middle estimate is 4.2-fold (0.62 log units) above the measured one, outside the stated range (below it).
By their numbers in this assay, from the lowest: compound 1; then compound 3; then compound 2.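

Methoxy in place of fluoro on this aromatic carbon, ortho to a methanesulfonamido group, gives a 2.7-fold lower number from compound 2 to compound 3 (0.43 log units; beyond the scatter) in this assay. The position therefore tolerates the larger methoxy group, and the change moves toward a stronger inhibitor, though only modestly. Nothing measured here explains the direction of this step.

On these data alone, what a hydroxy group, an ethoxy group or a chlorine atom would do on this carbon remains open. So does whether methoxy would give a similar step on the core of compound 1.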